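This account rests on a few compounds, and the source may have more. Where it says the series, first, only, none or still open, it means among the compounds named here.

Among the compounds with values here, compound 2 `c1cc(-c2ncnc3c2cnn3CCN2CCCCC2)ccn1` gives the lowest of the two numbers so far: in an assay on HEK293 cells for displacement of a labelled ligand from Sigma non-opioid intracellular receptor 1 (Homo sapiens), read by scintillation counting, with a stated time of 120 min (on this read-out higher numbers stand for weaker inhibition and lower numbers for stronger inhibition), compound 2 gives 1720 nM, while compound 1 `COc1ccc(-c2ncnc3c2cnn3CCN2CCCCC2)cn1` gives 38300 nM. Within the data shown here, the one measured step, a 22-fold lower number from compound 1 to compound 2 (1.35 log units; beyond the scatter), changes the same aromatic carbon that is varied again here. Compound 3 `c1nc(-c2cnsc2)c2cnn(CCN3CCCCC3)c2n1` carries 1,2-thiazol-4-yl in place of pyridin-4-yl on an aromatic carbon. Since that earlier step at this position was large, a change of comparable size cannot be excluded, though its direction is not fixed by one step; compound 3 is therefore expected to show a 2.3-fold higher number from compound 2 to compound 3 (0.37 log units; beyond the scatter) and to give about 4000 nM, with a range from 800 nM to 20000 nM.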

Compound 3, inhibition constant: 475 nM
Compound 3: middle estimate off by 8.4-fold (0.93 log units), on the high side; measured number below the stated range.
By their numbers in this assay, from the lowest: compound 3; then compound 2; then compound 1.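

In this assay, a five-membered aromatic ring at this aromatic carbon gives a lower number than a six-membered one: 1,2-thiazol-4-yl in place of pyridin-4-yl gives a 3.6-fold lower number from compound 2 to compound 3 (0.56 log units; beyond the scatter) at this position. Set against 6-methoxypyridin-3-yl, the same group gives an 81-fold lower number from compound 1 to compound 3 (1.91 log units; beyond the scatter), so the range at this carbon is wider than the first step showed. Nothing available explains this change. The compounds shown leave open how an amine or a carboxylic acid would read at this carbon.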